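This account rests on a few compounds, and the source may have more. Where it says the series, first, only, none or still open, it means among the compounds named here.

Measured in a functional assay on MDA-MB-231 cells (Homo sapiens) for antiproliferative activity, read by sulforhodamine B assay, with a stated time of 72 h; on this read-out higher numbers stand for weaker inhibition and lower numbers for stronger inhibition:
- compound 1 `COc1cc(OC)c(/C=C2\CCC=CC2=O)c(OC)c1`: 5070 nM
- compound 2 `COc1cc(/C=C2\CN(C(=O)OCc3ccccc3)C=CC2=O)cc(OC)c1OC`: 24200 nM

Compound 2 gives the higher of the two numbers, and its gap to compound 1 lies beyond the scatter, so it is the weaker inhibitor of the pair. Compound 3 `COc1cc(/C=C2\CNC=CC2=O)cc(OC)c1OC` differs from compound 2 in one place: hydrogen in place of benzyloxycarbonyl on an amine nitrogen in a ring. Among the compounds with values here, no measured pair shows the size of this change, so the expectation stays close to compound 2 at 24200 nM. In this assay the expected step is none beyond the scatter, a 1.2-fold lower number from compound 2 to compound 3 (0.08 log units; within the scatter). The estimated value for compound 3 is 20000 nM, with an expected range of 6000 nM to 70000 nM.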

Compound 3, half-maximal inhibitory concentration: > 25000 nM
Compound 3 ended at the assay's limit; the forecaster's own chance of this, stated with the estimate: 20%; middle value at least 1.2-fold (0.09 log units) from the limit.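

Replacing benzyloxycarbonyl with hydrogen on the amine nitrogen in the ring brings no lower number in this assay, the step being an at least 1.0-fold higher number from compound 2 to compound 3 (0.01 log units; that floor lies within the scatter). Compound 3 gives > 25000 nM, which is a limit of the assay and not a number. The step therefore has only a floor, and its true size stays unfixed: the limit of > 25000 nM in this assay, at which 1 of the 3 values shown sits.

From the compounds shown here alone, whether a methyl or an acetyl group on this nitrogen gives a lower number than compound 2 stays open. So does whether any group at this position brings the series clearly below compound 2.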